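Compound 3: methoxy in place of trifluoromethyl

The source may report more compounds than this note shows. Statements on the series, on what has been measured and on what is new or still open speak of the compounds shown alone.

In an ADME assay on MT4 cells (Homo sapiens) for cytotoxicity (on this read-out higher numbers stand for lower toxicity in this test and lower numbers for higher toxicity in this test), compound 1 (`O=c1[nH]c2ccc(Cl)cc2n1S(=O)(=O)c1cc(C(F)(F)F)cc(C(F)(F)F)c1`) gives 32300 nM. Compound 2 (`O=c1[nH]c2ccc(Cl)cc2n1S(=O)(=O)c1cccc(C(F)(F)F)c1`) gives only a limit (> 331000 nM). Compound 3 (`COc1cccc(S(=O)(=O)n2c(=O)[nH]c3ccc(Cl)cc32)c1`) has methoxy in place of trifluoromethyl on an aromatic carbon. Among the compounds with values here, the one measured step is large (an at least 10-fold higher number from compound 1 to compound 2 (1.01 log units; beyond the scatter)) and also removes a trifluoromethyl, a different change that leaves compound 2 with no number to step from. No step beyond the scatter is expected in this assay (an at least 1.5-fold lower number from compound 2 to compound 3 (0.17 log units; that floor lies within the scatter)). For compound 3 the estimate is 220000 nM (expected range 60000 nM to 370000 nM).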

Compound 3, half-maximal cytotoxic concentration: > 368000 nM
Compound 3 was reported as a limit (the forecaster's own chance of this, stated with the estimate: 60%); middle value at least 1.6-fold (0.22 log units) from the limit.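

In this assay, within the data shown here, compound 2 and compound 3 both carry only limits, so no step between them can be read. The compounds shown leave open whether methoxy and trifluoromethyl differ at all on this read-out.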